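A few compounds are considered here, and "the series" means these few. Any claim that something is new, unique, unknown or untested is made for them only; others in the source may bear on it.

Compound 3 `CCCCCCCCCCCCCCCOC(=O)CCC(=O)N1CCN(CCCOc2cc3c(Nc4ccc(F)c(Cl)c4)ncnc3cc2OC)CC1` gives 81.1% in a functional assay on A549 cells (Homo sapiens) for cytotoxicity, read by MTT assay, with a stated time of 24 h, tested at 80 uM; a higher number here means a weaker effect of the compound at the concentration tested, a lower number a stronger effect; no other number in the set is higher, yet compound 2 `CCCCCCCCCCCCCCOC(=O)CCC(=O)N1CCN(CCCOc2cc3c(Nc4ccc(F)c(Cl)c4)ncnc3cc2OC)CC1` gives 77.2% and the two sit within the scatter of each other, a number 3.9 percentage points higher from compound 2 to compound 3 (within the scatter). Compound 1 `CCCCCCCCCCCOC(=O)CCC(=O)N1CCN(CCCOc2cc3c(Nc4ccc(F)c(Cl)c4)ncnc3cc2OC)CC1` gives 2.8%, far lower: a number 74.4 percentage points higher from compound 1 to compound 2 (beyond the scatter) and a number 78.3 percentage points higher from compound 1 to compound 3 (beyond the scatter). Compound 4 `CCCCCCCCCCCCCCCCCCCOC(=O)CCC(=O)N1CCN(CCCOc2cc3c(Nc4ccc(F)c(Cl)c4)ncnc3cc2OC)CC1` carries butyl in place of hydrogen on a saturated chain carbon, ten or more bonds along the chain from an oxygen next to a carbonyl group. The steps of the same kind starting from compound 1 were large, but the further methyl step stayed within the scatter, and compound 3 already lies near the top of the scale. Another lengthening of the chain is therefore expected to move the number by no more than the scatter, a number 0.9 percentage points higher from compound 3 to compound 4 (within the scatter). Compound 4 is expected at 82%, within 68% to 94%.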

Compound 4, a percentage reported as activity, at one concentration (the size of the read-out at that concentration, not a potency): 88.4%
The estimate for compound 4 lay 6.4 percentage points below the measured number, within the range that was stated.
By their numbers in this assay, from the lowest: compound 1; then compounds 2, 3 and 4 (each within the scatter of the next, the first and the last beyond it).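

In this assay butyl in place of hydrogen on a saturated chain carbon gives a number 7.3 percentage points higher from compound 3 to compound 4 (within the scatter) and so adds no readable change to compound 3. Pentyl in place of hydrogen gives a number 11.2 percentage points higher from compound 2 to compound 4 (beyond the scatter) as the only step among compounds 2, 3 and 4 beyond the scatter, and octyl in place of hydrogen gives a number 85.6 percentage points higher from compound 1 to compound 4 (beyond the scatter) as the largest step in the series. Nothing at hand bears on what lies behind these steps.

Open: where between the chains of compound 1 and compound 2 the large step arises, and whether an amine or a carboxylic acid in place of hydrogen on the same saturated chain carbon would hold the number of compound 4.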